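Hydroxy in place of chloro: compound 3 to compound 4

The source may hold more compounds than are shown below. What is called first, only, known or untested is meant among the compounds shown, and "the series" means these compounds.

Measured in a functional assay on MC-38 cells (Mus musculus) for antiproliferative activity, read by colorimetric assay and MTT assay; a lower number here means a stronger inhibitor, a higher number a weaker inhibitor:
- compound 1 `O=S(=O)(Nc1cccc2cc(O)[nH]c12)c1ccc(Cl)cc1` gives 4.5 ug/mL
- compound 2 `Nc1ccc(S(=O)(=O)Nc2cccc3cc[nH]c23)cc1` gives 6.1 ug/mL
- compound 3 `Nc1ccc(S(=O)(=O)Nc2cccc3cc(Cl)[nH]c23)cc1` gives 2.9 ug/mL

Compound 3 lies within the scatter of compound 1 and beyond the scatter of compound 2, which has the higher number. Compound 4 `Nc1ccc(S(=O)(=O)Nc2cccc3cc(O)[nH]c23)cc1` carries hydroxy in place of chloro on an aromatic carbon next to the ring nitrogen (hydroxy in place of chloro on an aromatic carbon). Going by the values given here, the one measured step at this place is modest: a 2.1-fold lower number from compound 2 to compound 3 (0.32 log units; beyond the scatter). Compound 1 also carries hydroxy there and differs from compound 4 elsewhere. Compound 1 gives 4.5 ug/mL and lies within the scatter of compound 3. A small rise within the scatter is therefore expected in this assay. The expected change is a 1.4-fold higher number from compound 3 to compound 4 (0.14 log units; within the scatter) in this read-out. For compound 4 the estimate is 4 ug/mL with an expected range from 1.8 ug/mL to 8.5 ug/mL in this read-out.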

Compound 4, half-maximal inhibitory concentration: 1.8 ug/mL
The estimate for compound 4 lay 2.2-fold (0.35 log units) above the measured number, and the stated range covers the measured number.
By their numbers in this assay, from the lowest: compounds 4, 3, 1 and 2 (each within the scatter of the next, the first and the last beyond it).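

In this assay, a 1.6-fold lower number from compound 3 to compound 4 (0.21 log units; within the scatter) leaves hydroxy and chloro on this aromatic carbon next to the ring nitrogen unresolved, whereas a 3.4-fold lower number from compound 2 to compound 4 (0.53 log units; beyond the scatter) shows that hydroxy in place of hydrogen here gives a step beyond the scatter. Going by these compounds alone, with hydroxy held at this place, a 2.5-fold lower number from compound 1 to compound 4 (0.40 log units; beyond the scatter) gives the first reading of amino in place of chloro on an aromatic carbon, and that step also lies beyond the scatter. On these data alone, how a methoxy group, an amine or a carboxylic acid on this carbon would compare with hydroxy remains open. No available evidence accounts for these steps.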